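Replacing the oxolanyl side chain with a dimethylisoxazole

The source may report more compounds than this note shows. Statements on the series, on what has been measured and on what is new or still open speak of the compounds shown alone.

Compound 3 `Cc1cc(C)c(CN2CCc3c(Cl)cc([C@H](CO)[C@@H]4CCCO4)c(Cl)c3C2=O)c(=O)[nH]1` gives 41 nM in an assay on cells for inhibition of histone-lysine N-methyltransferase EZH2 (Homo sapiens), read by ELISA, with a stated time of 72 h (a higher number here means a weaker inhibitor, a lower number a stronger inhibitor), the highest of the three numbers shown. Compound 2 `Cc1cc(C)c(CN2CCc3c(Cl)cc([C@H](CO)[C@H]4CCCO4)c(Cl)c3C2=O)c(=O)[nH]1` gives 40 nM; the pair differ only in configuration as drawn (the fact that compounds 2 and 3 differ only in the configuration as drawn), and a 1.0-fold higher number from compound 2 to compound 3 (0.01 log units; within the scatter). Compound 1 `Cc1cc(C)c(CN2CCc3c(Cl)cc([C@H](CO)[C@H]4CCOC4)c(Cl)c3C2=O)c(=O)[nH]1` gives 10 nM; the steps of a 4.0-fold higher number from compound 1 to compound 2 (0.60 log units; beyond the scatter) and a 4.1-fold higher number from compound 1 to compound 3 (0.61 log units; beyond the scatter) are both modest. Compound 4 `Cc1cc(C)c(CN2CCc3c(Cl)cc(-c4c(C)noc4C)c(Cl)c3C2=O)c(=O)[nH]1` awaits measurement; the change from compound 3 is a group of 7 heavy atoms (5 carbon, 1 nitrogen, 1 oxygen; one five-membered aromatic ring with 2 hetero atoms) in place of a group of 8 heavy atoms (6 carbon, 2 oxygen; one five-membered non-aromatic ring with 1 hetero atom), on an aromatic carbon. Going by the values given here, none of the measured steps involves an aromatic replacement at this carbon, so they bear on the step only in showing that variation at this position has moved the numbers within a modest range. The step of a 1.2-fold higher number from compound 3 to compound 4 (0.09 log units; within the scatter) is therefore expected to stay small. Compound 4 is estimated at 50 nM, between 10 nM and 250 nM.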

Compound 4, half-maximal inhibitory concentration: 17 nM
Beside the measured number, compound 4's estimate is 2.9-fold (0.47 log units) above it; the range from low to high includes it.
By their numbers in this assay, from the lowest: compounds 1 and 4 (each within the scatter of the next); then compounds 2 and 3 (each within the scatter of the next).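

An aromatic 3,5-dimethyl-1,2-oxazol-4-yl group is tolerated on this aromatic carbon in place of the chain with its oxolanyl ring: a 2.4-fold lower number from compound 3 to compound 4 (0.38 log units; beyond the scatter) and a 2.4-fold lower number from compound 2 to compound 4 (0.37 log units; beyond the scatter) are both modest, while a 1.7-fold higher number from compound 1 to compound 4 (0.23 log units; within the scatter) stays within the scatter. The chain with its defined stereocentres is therefore not required for a number at this level. The steps from compounds 2 and 3 amount to nearly one comparison made twice, and configuration in the leaving group cannot be judged from them: the fact that compounds 2 and 3 differ only in the configuration as drawn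

As far as these compounds go, whether a phenyl, a pyridine or an aminomethyl group on this carbon would hold the number remains open. Also open, from the compounds shown here alone, is whether either methyl group of the 3,5-dimethyl-1,2-oxazol-4-yl group matters.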